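Piperidinyl versus carbamoylpiperazinylmethyl at the chemokine receptor

The source may report more compounds than this note shows. Statements on the series, on what has been measured and on what is new or still open speak of the compounds shown alone.

Measured compounds:
compound 1, `c1ccc2c(c1)CN[C@@H](CN(CC[C@@H]1CCCNC1)[C@H]1CCCc3cccnc31)C2`: 161 nM
compound 2, `c1ccc2c(c1)CN[C@@H](CN(CCN1CCNCC1)[C@H]1CCCc3cccnc31)C2`: 553 nM
compound 3, `NC(=O)N1CCN(CCCN(C[C@H]2Cc3ccccc3CN2)[C@H]2CCCc3cccnc32)CC1`: 959 nM

In a functional assay on CCRF-CEM cells for antagonist activity at C-X-C chemokine receptor type 4 (Homo sapiens), read by calcium flux, with stated times of 25 min and 90 s (on this read-out higher numbers stand for weaker inhibition and lower numbers for stronger inhibition), compound 3 has the highest number of the three; compound 2 lies within the scatter of it, compound 1 beyond it. Compound 4, `c1ccc2c(c1)CN[C@@H](CN(CC[C@H]1CCCNC1)[C@H]1CCCc3cccnc31)C2`, differs from compound 3 by piperidin-3-yl in place of (4-carbamoylpiperazin-1-yl)methyl on a saturated chain carbon, two bonds along the chain from an amine nitrogen. It carries the piperidin-3-yl of compound 1, though with the opposite configuration at the defined stereocentre. The reverse of this step is on record: a 6.0-fold higher number from compound 1 to compound 3 (0.77 log units; beyond the scatter), and the related change gave a 3.4-fold higher number from compound 1 to compound 2 (0.54 log units; beyond the scatter). A move back toward compound 1 is therefore expected in this assay, tempered by the changed stereocentre: an estimated 3.2-fold lower number from compound 3 to compound 4 (0.50 log units; beyond the scatter), giving compound 4 an expected 300 nM, within 100 nM to 1000 nM.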

Compound 4, half-maximal inhibitory concentration: 16 nM
Compound 4: middle estimate off by 19-fold (1.27 log units), on the high side, and the stated range ends above it.
By their numbers in this assay, from the lowest: compound 4; then compound 1; then compounds 2 and 3 (each within the scatter of the next).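

In this assay, the configuration at the piperidin-3-yl stereocentre proves decisive on its own, with a 10-fold lower number from compound 1 to compound 4 (1.00 log units; beyond the scatter), and this step can be read as a pure stereochemical effect: the fact that compounds 1 and 4 differ only in the configuration as drawn. Drawn as in compound 4, piperidin-3-yl also stands much further from the piperazine-bearing groups than the earlier steps showed, with a 35-fold lower number from compound 2 to compound 4 (1.54 log units; beyond the scatter) and a 60-fold lower number from compound 3 to compound 4 (1.78 log units; beyond the scatter).

Still open, from the compounds shown here alone, is how a piperidin-4-yl or a pyrrolidin-3-yl would compare at this place. Also open, going by these compounds, is whether a longer chain carrying the piperidin-3-yl of compound 4 would keep its number.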